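Swapping a chloro for an amino on the purine-like core

The compounds below may be only part of what the source reports. "The series", "measured", "known", "first", "only" and "open" are said of these compounds alone.

Three compounds of one family share a fused two-ring core. Compound 1 `ClCc1ccccc1Cn1cnc2c(Cl)nc(Cl)nc21` carries a chloromethyl group on its benzyl arm; in a functional assay on SNB-19 cells (Homo sapiens) for cytotoxicity, read by sulforhodamine B assay, with a stated time of 48 h (a higher number here means that more compound is tolerated, a lower number that less compound is tolerated), compound 1 gives "not determined" (no result reported). Compound 2 `ClCc1cccc(Cn2cnc3c(Cl)ncnc32)c1` has a single chloro on the core, and in this assay compound 2 reaches only the limit of > 100000 nM. Among the compounds with values here, compound 3 `ClCc1cccc(Cn2cnc3c(Cl)nc(Cl)nc32)c1` adds a second chloro, and in this assay compound 3 gives 8920 nM, the only plain number among the three. Within the data shown here, the gain from adding that chloro is an at least 11-fold lower number from compound 2 to compound 3 (1.04 log units; beyond the scatter); the only evidence behind it is the limit of > 100000 nM in this assay, at which 1 of the 3 values shown sits.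

Compound 4 `Nc1nc(Cl)c2ncn(Cc3cccc(CCl)c3)c2n1` changes (amino in place of chloro on an aromatic carbon), so the very chloro that brought the gain is exchanged for amino. Since compound 2 without that chloro stayed at its limit, and a hydrogen is not an amino, a loss is expected, but a smaller one. Compound 4 is therefore expected to give about 35000 nM, between 9000 nM and 130000 nM. That estimate means an expected step of a 3.9-fold higher number from compound 3 to compound 4 (0.59 log units; beyond the scatter).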

Compound 4, concentration lethal to 50% of the cells: 46800 nM
Estimate against measurement, compound 4: 1.3-fold (0.13 log units) below; low and high end bracket the measured number.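

The earlier compounds shown here showed only that a chloro on this carbon, between two ring nitrogen atoms, lowers the number compared with hydrogen; compound 4 shows that the outcome also depends on which group takes that place, with a 5.2-fold higher number from compound 3 to compound 4 (0.72 log units; beyond the scatter) in this assay. Amino on this carbon still gives a lower number than hydrogen, with an at least 2.1-fold lower number from compound 2 to compound 4 (0.32 log units; beyond the scatter). The size of this second step is tied to a limit of the assay, not to a plain number: the limit of > 100000 nM in this assay, at which 1 of the 4 values shown sits.

The compounds shown leave open whether another group on this carbon, such as methoxy or methylamino, would fall nearer compound 3 or nearer compound 4. Within the data shown here, also open is what the same exchange would do at the other chloro on the core, the one shared by compound 2, compound 3 and compound 4.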